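A Nitro Group Added to an Inactive Quinoline Ether

A few compounds are considered here, and "the series" means these few. Any claim that something is new, unique, unknown or untested is made for them only; others in the source may bear on it.

Compound 1 `CNC(=O)c1cc(Oc2ccc(NS(=O)(=O)c3ccc(C(F)(F)F)cc3Br)cc2)ccn1` gives only a limit of the assay, > 40000 nM, in a functional assay on PLC-PRF-5 cells (Homo sapiens) for inhibition; on this read-out lower numbers stand for stronger inhibition and higher numbers for weaker inhibition.
Compound 2 `O=[N+]([O-])c1cc(C(F)(F)F)ccc1S(=O)(=O)Nc1ccc(Oc2ccnc3c([N+](=O)[O-])cccc23)cc1` gives only a limit, > 40000 nM, in this assay.
Compound 3 `O=S(=O)(Nc1ccc(Oc2ccnc3ccccc23)cc1)c1ccc(C(F)(F)F)cc1Br` gives only a limit, > 40000 nM, in this assay.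

Compound 3 therefore stands where every measured compound stands: at the limit, with no number to rank it (the limit of > 40000 nM in this assay, at which 3 of the 3 values shown sit). Among the measured compounds shown here, the single one-point step, a step that the two limits leave unreadable from compound 1 to compound 3, is unreadable because both ends are limits.

Compound 4 `O=[N+]([O-])c1cccc2c(Oc3ccc(NS(=O)(=O)c4ccc(C(F)(F)F)cc4Br)cc3)ccnc12` differs from compound 3 by nitro in place of hydrogen on an aromatic carbon. For the measured compounds named here, no measured step bears directly on this change, and the one step recorded gives no size at all. Compound 2 also carries nitro groups and also reaches only the limit, so nothing measured points toward inhibition appearing in compound 4.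

Compound 4 is therefore expected to stay at the limit too, with an estimate of 60000 nM (range 20000 nM to 200000 nM). The expected step that the limit leaves unreadable from compound 3 to compound 4 in this assay is no change beyond the scatter, and against a limit it cannot be read as a true number.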

Compound 4, half-maximal inhibitory concentration: > 40000 nM
Compound 4 was reported as a limit; the forecaster's own chance of this, stated with the estimate: 85%; the middle value is on the limit's open side.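

Neither the step from compound 3 to compound 4 nor the step from compound 2 to compound 4 can be read, as all three compounds give only a limit: the limit of > 40000 nM in this assay, at which 4 of the 4 values shown sit.

The compounds shown leave open whether any change to the shared core brings measurable inhibition in this assay, and how the nitro and bromo groups would then rank.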